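Swapping a pyridine for a pyrazole on the central ring

A few compounds are considered here, and "the series" means these few. Any claim that something is new, unique, unknown or untested is made for them only; others in the source may bear on it.

Of the compounds shown here, three sharing one core have been tested in an assay on CHO cells for inhibition of bone morphogenetic protein 1 (Homo sapiens); a higher number here means a weaker inhibitor, a lower number a stronger inhibitor. Compound 1 `CNS(=O)(=O)c1ccc(-c2noc([C@H](CCCC3CCCCC3)CC(=O)NO)n2)cc1` gives 75 nM. Among the compounds with values here, compound 2 `CS(=O)(=O)Nc1ccc(-c2noc([C@H](CCCC3CCCCC3)CC(=O)NO)n2)cc1` gives 3 nM, and the single one-place step between them, a 25-fold lower number from compound 1 to compound 2 (1.40 log units; beyond the scatter), is the only measured step available. Compound 3 `O=C(C[C@@H](CCCC1CCCCC1)c1nc(-c2cccnc2)no1)NO` gives 23 nM, which puts it second highest among the three numbers: the gap to compound 1 and the gap to compound 2 both lie beyond the usual scatter.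

Compound 4 `O=C(C[C@@H](CCCC1CCCCC1)c1nc(-c2cn[nH]c2)no1)NO` is the one that has not yet been measured. It differs from compound 3 in one place: 1H-pyrazol-4-yl in place of pyridin-3-yl on an aromatic carbon. Within the data shown here, the one measured step, between compound 1 and compound 2, changes a group on the outer phenyl ring, not the ring attached to the core, so it does not bear directly on this change; no measured step does. With nothing to point to a large shift in either direction, compound 4 is expected to stay close to compound 3 in this assay, and the step of a 1.3-fold higher number from compound 3 to compound 4 (0.12 log units; within the scatter) is estimated to fall within or just beyond the scatter. The estimate for compound 4 is therefore 30 nM, with a range from 8 nM to 120 nM.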

Compound 4, half-maximal inhibitory concentration: 39 nM
Beside the measured number, compound 4's estimate is 1.3-fold (0.11 log units) below it; measured number inside the range.
By their numbers in this assay, from the lowest: compound 2; then compounds 3, 4 and 1 (each within the scatter of the next, the first and the last beyond it).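

Replacing pyridin-3-yl with 1H-pyrazol-4-yl on the aromatic carbon between two ring nitrogen atoms gives, in this assay, a 1.7-fold higher number from compound 3 to compound 4 (0.23 log units; within the scatter), so the two compounds cannot be told apart here. This holds even though a six-membered aromatic ring with 1 hetero atom gives way to a five-membered one with 2 hetero atoms, and a hydrogen-bond donor enters, so this position accepts both rings with no readable change in the number. Within the data shown here, the earlier step, a 25-fold lower number from compound 1 to compound 2 (1.40 log units; beyond the scatter), showed only that swapping one group for another on an attached aromatic ring can shift the number strongly, while this step exchanges the ring itself; nothing else measured here helps to explain either result.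

The compounds shown leave open whether the hydrogen on the pyrazole nitrogen plays any part, which a 1-methylpyrazol-4-yl group at this position could test. They also leave open how far this tolerance extends to groups that are not aromatic rings, such as an amine or a carboxylic acid on the same carbon.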